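The source may hold more compounds than are shown below. What is called first, only, known or untested is meant among the compounds shown, and "the series" means these compounds.

Measured compounds:
Compound 1, `CC(C)(C)NCc1cc(Cl)cc(Nc2nc3ccccc3[nH]2)c1O`, a limit only: > 50000 nM.
Compound 2, `CCN(CC)Cc1cc(Nc2nc3ccccc3n2Cc2ccc(C#N)cc2)ccc1O`, a limit only: > 50000 nM.
Compound 3, `CC(C)(C)NCc1cc(C(C)(C)C)cc(Nc2nc3cc(F)c(F)cc3[nH]2)c1O`, a number: 34200 nM.

Three compounds were measured in an ADME assay on CHO cells (Cricetulus griseus) for inhibition, read by MTT assay; a higher number here means a weaker inhibitor, a lower number a stronger inhibitor. Compound 1 returns only a limit of the assay, > 50000 nM. Compound 2 likewise returns only a limit of the assay, > 50000 nM. Compound 3 returns a number, 34200 nM, which is weak inhibition. Going by the values given here, no pair of measured compounds differs in a single place, so no measured step is available. Compound 2 stands at the limit of > 50000 nM in this assay, at which 2 of the 3 values shown sit.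

Compound 4, `CCN(CC)Cc1cc(Nc2nc3ccccc3[nH]2)ccc1O`, has not yet been measured. It differs from compound 2 by hydrogen in place of 4-cyanobenzyl on an aromatic nitrogen. Compound 1 and compound 3 also carry hydrogen on that ring nitrogen, and both show weak inhibition, so there is no sign that this change should strengthen inhibition. The step of a number no higher from compound 2 to compound 4 (the limit leaves the size open) is expected to be none beyond the scatter, with a further limit the most likely outcome. Compound 4 is therefore estimated at 50000 nM, with a range from 20000 nM to 120000 nM.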

Compound 4, half-maximal inhibitory concentration: > 50000 nM
Compound 4: no number, only a limit (the forecaster's own chance of this, stated with the estimate: 70%); the middle value sits exactly at the limit.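

Going by these compounds alone, compound 2 and compound 4 both return only a limit in this assay, so no step between them can be read. Compound 2 stands at: the limit of > 50000 nM in this assay, at which 3 of the 4 values shown sit.

The compounds shown leave open whether hydrogen in place of 4-cyanobenzyl on an aromatic nitrogen changes inhibition at all.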